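Isopropyl on the saturated ring of compound 1

A few compounds are considered here, and "the series" means these few. Any claim that something is new, unique, unknown or untested is made for them only; others in the source may bear on it.

In a functional assay on the whole organism with Mus musculus as the target (on this read-out higher numbers stand for an effect only at larger amounts of compound and lower numbers for an effect already at smaller amounts), compound 1 (`Cc1c(C)c2c(c(C)c1N)CC(C)(C)O2`) gives 7.8 mg/kg. Within the data shown here, this is the only true number available, since the other two results are limits. Compound 2 (`Cc1c(N)c(C)c2c(c1CN1CCCCC1)OC(C)(C)C2`) reads > 50 mg/kg, which is a limit of the assay. Compound 3 (`Cc1c(C)c2c(c(C)c1N)CC(C)(CSCCO)O2`) reads > 50 mg/kg, again a limit of the assay.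

Compound 4 (`Cc1c(C)c2c(c(C)c1N)C(C(C)C)C(C)(C)O2`) is the next case. Its change from compound 1 is isopropyl in place of hydrogen on a saturated ring carbon, next to the ring atom that bears two methyl groups.

Two measured steps offer guidance: an at least 6.4-fold higher number from compound 1 to compound 2 (0.80 log units; beyond the scatter) and an at least 6.4-fold higher number from compound 1 to compound 3 (0.80 log units; beyond the scatter). Both of these steps end at the limit of > 50 mg/kg in this assay, at which 2 of the 3 values shown sit. As far as these compounds go, their true size therefore stays open. Both also replace hydrogen on saturated chain carbons, not on the ring carbon changed in compound 4, and they bring in different groups. They support an expected upward direction in this assay, but only weakly, so a modest rise is anticipated. The expected change is a 2.3-fold higher number from compound 1 to compound 4 (0.36 log units; beyond the scatter). For compound 4 the estimated value is 18 mg/kg, with an expected range of 5 mg/kg to 50 mg/kg.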

Compound 4, dose for 50% inhibition: 14 mg/kg
Estimate against measurement, compound 4: 1.3-fold (0.11 log units) above, within the range that was stated.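

In this assay, isopropyl in place of hydrogen on this saturated ring carbon gives a 1.8-fold higher number from compound 1 to compound 4 (0.25 log units; within the scatter). This ring carbon, next to the ring atom that bears two methyl groups, therefore takes an added group of 3 heavy atoms, all carbon, with no change beyond the scatter, and compound 4 keeps a true number on this read-out. The earlier changes at saturated chain carbons gave no such measure: compound 2 and compound 3 both stay at a limit of the assay, and the size of their steps cannot be read because they end there: the limit of > 50 mg/kg in this assay, at which 2 of the 4 values shown sit.

Isopropyl is the only group the compounds shown place on this ring carbon, so they leave open how an amine, a carboxylic acid or a longer alkyl chain at the same carbon would read in this assay. They also leave open whether a smaller group such as methyl or ethyl there would behave like isopropyl, and whether the same isopropyl group would be accepted at the saturated chain carbons changed in compound 2 and compound 3.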